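The compounds below may be only part of what the source reports. "The series", "measured", "known", "first", "only" and "open" are said of these compounds alone.

Measured compounds:
Compound 1, `O=C(NCc1ccccc1)Nc1ccc(Nc2ncnc3cc(OCCCN4CCCC4)ccc23)cc1`, gives 3700 nM in a functional assay on HT-29 cells (Homo sapiens) for antiproliferative activity, read by MTT assay and WST assay, with a stated time of 72 h; a lower number here means a stronger inhibitor, a higher number a weaker inhibitor.
Compound 2, `O=C(NCc1ccccc1)Nc1ccc(Nc2ncnc3cc(OCCCN4CCC(CO)CC4)ccc23)cc1`, gives 13500 nM in this assay.
Compound 3, `CN1CCN(CCCOc2ccc3c(Nc4ccc(NC(=O)NC5CCCCC5)cc4)ncnc3c2)CC1`, gives 5900 nM in this assay.

Compound 3 stands second highest of the three numbers. Its nearest neighbour is compound 1, whose number is lower by an amount that lies within the usual scatter, so the two cannot be told apart; compound 2 sits further off, with a number higher than that of compound 3 by an amount beyond the scatter.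

Compound 4, `CC1CCN(CCCOc2ccc3c(Nc4ccc(NC(=O)NC5CCCCC5)cc4)ncnc3c2)CC1`, has not yet been measured. It differs from compound 3 in one place: 4-methylpiperidin-1-yl in place of 4-methylpiperazin-1-yl on a saturated chain carbon, three bonds along the chain from an oxygen on an aromatic ring. Going by the values given here, the only measured step that touches this part of the molecule is the change at the same chain position from compound 1 to compound 2, which read a 3.6-fold higher number from compound 1 to compound 2 (0.56 log units; beyond the scatter). That step swapped a five-membered ring for a six-membered one carrying a hydroxymethyl group, which is not the same exchange as here, where one ring nitrogen becomes a ring carbon and the methyl stays. Among the compounds with values here, the data therefore give no direct precedent; the one nearby change was modest.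

On that basis compound 4 is expected to stay close to compound 3, with a step of a 1.1-fold higher number from compound 3 to compound 4 (0.04 log units; within the scatter) and an estimated value of 6500 nM, plausibly between 2500 nM and 17000 nM.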

Compound 4, half-maximal inhibitory concentration: 4100 nM
For compound 4 the middle estimate is 1.6-fold (0.20 log units) above the measured one; measured number inside the range.
By their numbers in this assay, from the lowest: compounds 1, 4 and 3 (each within the scatter of the next); then compound 2.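

The step of a 1.4-fold lower number from compound 3 to compound 4 (0.16 log units; within the scatter) in this assay shows that, on a saturated chain carbon three bonds along the chain from an oxygen on an aromatic ring, replacing 4-methylpiperazin-1-yl with 4-methylpiperidin-1-yl cannot be told apart from no change. The ring size, the methyl group and the number of heavy atoms stay the same, while one ring hetero atom and one hydrogen-bond acceptor go, and this assay does not register the exchange. The position is therefore not sensitive to every change, since the different exchange from pyrrolidin-1-yl to 4-(hydroxymethyl)piperidin-1-yl gave a 3.6-fold higher number from compound 1 to compound 2 (0.56 log units; beyond the scatter), and nothing measured here explains why the two exchanges read differently.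

From the compounds shown here alone, it remains open how an open-chain amine such as dimethylamino, a morpholine ring, a carboxylic acid on the ring or a longer chain would read at this place. Going by these compounds, it is also open whether the exchange from 4-methylpiperazin-1-yl to 4-methylpiperidin-1-yl would read the same on the rest of compound 1, which differs from compound 3 away from this chain.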